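From benzyl to 4-chlorobenzyl on compound 3

The compounds below may be only part of what the source reports. "The series", "measured", "known", "first", "only" and "open" are said of these compounds alone.

In a physicochemical assay for solubility, with a stated time of 3 days, at pH 2 (on this read-out higher numbers stand for higher solubility and lower numbers for lower solubility), compound 1 `NC(=O)c1ccc2[nH]c(-c3ccc(OCCCN4CCCCC4)cc3)nc2c1` reads > 400000 nM, which is a limit of the assay and not a number. For compound 2 `COc1ccc(CN2CCCC(COc3ccc(-c4nc5cc(C(N)=O)ccc5[nH]4)cc3)C2)cc1` the entry is "not determined" (no result reported). For the measured compounds named here, that leaves compound 3 `NC(=O)c1ccc2[nH]c(-c3ccc(OCCC4CCN(Cc5ccccc5)CC4)cc3)nc2c1` at 110000 nM as the only true number so far.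

Compound 4 `NC(=O)c1ccc2[nH]c(-c3ccc(OCCC4CCN(Cc5ccc(Cl)cc5)CC4)cc3)nc2c1` differs from compound 3 in one place: chloro in place of hydrogen on an aromatic carbon, para to a large group, so that benzyl becomes 4-chlorobenzyl (chloro in place of hydrogen on an aromatic carbon). Going by the values given here, no measured pair differs in just one place, so this expectation is a rough one. A modest fall in this assay is expected, an estimated 2.2-fold lower number from compound 3 to compound 4 (0.34 log units; beyond the scatter). For compound 4 the estimated value is 50000 nM, with an expected range from 15000 nM to 130000 nM.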

Compound 4, solubility: 179000 nM
Compound 4: the middle estimate sits 3.6-fold (0.55 log units) below what was measured, outside the stated range (above it).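

In this assay, chloro in place of hydrogen on this aromatic carbon gives a 1.6-fold higher number from compound 3 to compound 4 (0.21 log units; within the scatter). For the compounds shown here, this is the first comparison of two compounds that differ in one place, and at this position the change leaves no difference that can be told from the scatter. Both values here are true numbers, so the step can be read in full, while compound 1 offers only a limit: the limit of > 400000 nM in this assay, at which 1 of the 4 values shown sits.

From the compounds shown here alone, whether a methoxy group, an amine or a carboxylic acid at this position would behave the same remains open. So does the effect of chloro on another carbon of that ring.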